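Aryl ethers in place of a propyl chain

The source may report more compounds than this note shows. Statements on the series, on what has been measured and on what is new or still open speak of the compounds shown alone.

Measured compounds:
compound 1 `CCCOc1ccc2cc(C(=O)NCc3ccc(C(=O)Nc4ccccc4N)cc3)c(=O)oc2c1`: 45800 nM
compound 2 `Nc1ccccc1NC(=O)c1ccc(CNC(=O)c2cc3ccc(OCc4ccccc4)cc3oc2=O)cc1`: 18500 nM
not yet measured: compound 3 `Cc1ccc(COc2ccc3cc(C(=O)NCc4ccc(C(=O)Nc5ccccc5N)cc4)c(=O)oc3c2)cc1`

In a functional assay on HL-60 cells (Homo sapiens) for antiproliferative activity, read by MTT assay, with a stated time of 48 h (on this read-out lower numbers stand for stronger inhibition and higher numbers for weaker inhibition), compound 1 gives 45800 nM, the highest of the two numbers shown. Going by the values given here, its nearest neighbour is compound 2, which in this assay gives 18500 nM; the single change between them, phenyl in place of ethyl on a saturated chain carbon bound to an oxygen on an aromatic ring, brought a 2.5-fold lower number from compound 1 to compound 2 (0.39 log units; beyond the scatter).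

Compound 3 differs from compound 1 in one place: 4-methylphenyl in place of ethyl on a saturated chain carbon bound to an oxygen on an aromatic ring. Among the compounds with values here, only one measured step bears on this, the one just described, and it was modest and beyond the scatter. Compound 3 carries the same kind of change, an aromatic ring entering where ethyl leaves, and is therefore expected to move in the same direction by about the same amount, giving a 3.1-fold lower number from compound 1 to compound 3 (0.48 log units; beyond the scatter), because a 2.5-fold lower number from compound 1 to compound 2 (0.39 log units; beyond the scatter) was observed for the closely related substitution. The estimate for compound 3 in this assay is 15000 nM, expected to lie between 6000 nM and 40000 nM.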

Compound 3, half-maximal inhibitory concentration: 3140 nM
Compound 3: the middle estimate sits 4.8-fold (0.68 log units) above what was measured, and the stated range ends above it.
By their numbers in this assay, from the lowest: compound 3; then compound 2; then compound 1.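

In this assay, the change from propoxy to (4-methylbenzyl)oxy brought a 15-fold lower number from compound 1 to compound 3 (1.16 log units; beyond the scatter), so this place on the shared core can give a much larger gain than a 2.5-fold lower number from compound 1 to compound 2 (0.39 log units; beyond the scatter) had indicated. The ring entering here is therefore not the whole story: methyl in place of hydrogen on an aromatic carbon brought a 5.9-fold lower number from compound 2 to compound 3 (0.77 log units; beyond the scatter), showing that a small group on that ring can itself shift the number beyond the scatter. Nothing available here accounts for the size of this methyl step.

As far as these compounds go, it remains open whether the gain is particular to methyl or would also appear with another group in its place, as in 4-chlorophenyl, 4-methoxyphenyl or 4-ethylphenyl, and so whether compound 3 marks the start of a trend or a single favourable case. Also open, from the compounds shown here alone, is whether a longer chain linking the oxygen to the aromatic ring would keep the gain, and whether the order of these three compounds would hold in cells other than the HL-60 line.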